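The compounds below may be only part of what the source reports. "The series", "measured", "known", "first", "only" and "open" are said of these compounds alone.

Measured in a functional assay on MCF7 cells (Homo sapiens) for cytotoxicity, read by MTT assay, with a stated time of 24 h; a higher number here means a weaker inhibitor, a lower number a stronger inhibitor:
- compound 1 `CCNc1cc(-c2ccc(NC(=O)Nc3ccc(C(F)(F)F)cc3)cc2OC)ccn1` gives 19500 nM
- compound 2 `CCNc1cc(-c2ccc(NC(=O)Nc3cccc(Cl)c3)cc2F)ccn1` gives 6940 nM
- compound 3 `CCNc1cc(-c2ccc(NC(=O)Nc3ccc(OC)cc3)cc2F)ccn1` gives 14100 nM

Compound 3 lies within the scatter of compound 1 but apart from compound 2, as a 2.0-fold higher number from compound 2 to compound 3 (0.31 log units; beyond the scatter) shows. Compound 4 `CCNc1cc(-c2ccc(NC(=O)Nc3ccc(C(F)(F)F)cc3)cc2F)ccn1` carries trifluoromethyl in place of methoxy on an aromatic carbon, para to a large group trifluoromethyl in place of methoxy on an aromatic carbon in comparison with compound 3. Going by the values given here, only that modest step from compound 2 touches this aryl group, and it involves a different replacement. Compound 1 has the same 4-(trifluoromethyl)phenyl at 19500 nM on a differently substituted core. In this assay no step beyond the scatter is therefore expected, with a slight lean towards a lower number. The expected change is a 1.3-fold lower number from compound 3 to compound 4 (0.11 log units; within the scatter) in this estimate. For compound 4 the estimated value is 11000 nM within an expected range of 5000 nM to 23000 nM overall.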

Compound 4, half-maximal inhibitory concentration: 8020 nM
Estimate against measurement, compound 4: 1.4-fold (0.14 log units) above; measured number inside the range.
By their numbers in this assay, from the lowest: compounds 2, 4, 3 and 1 (each within the scatter of the next, the first and the last beyond it).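

In this assay the change from methoxy to trifluoromethyl on this aromatic carbon stays within the scatter (a 1.8-fold lower number from compound 3 to compound 4 (0.25 log units; within the scatter)), and so does the change from 3-chlorophenyl to 4-(trifluoromethyl)phenyl (a 1.2-fold higher number from compound 2 to compound 4 (0.06 log units; within the scatter)). With 4-(trifluoromethyl)phenyl held constant, fluoro in place of methoxy on the core gives a modest step beyond the scatter (a 2.4-fold lower number from compound 1 to compound 4 (0.39 log units; beyond the scatter)). No available evidence bears on the reason for these steps. The compounds shown leave open how an amine or a carboxylic acid at this place would compare with methoxy and trifluoromethyl. They also leave open whether a chloro group in place of fluoro on the core would retain this level of activity.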